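This account rests on a few compounds, and the source may have more. Where it says the series, first, only, none or still open, it means among the compounds named here.

In a functional assay on RS4-11 cells (Homo sapiens) for inhibition, read by CCK-8 assay, with a stated time of 48 h (a higher number here means a weaker inhibitor, a lower number a stronger inhibitor), two compounds have been measured. Compound 1 `O=C(Nc1cccc([N+](=O)[O-])c1)N1CCN(S(=O)(=O)c2sccc2-c2ccccc2Oc2ccc(O)c(O)c2)CC1` gives 9800 nM. Compound 2 `O=C(NCCNS(=O)(=O)c1ccc(-c2ccccc2Oc2ccc([N+](=O)[O-])c([N+](=O)[O-])c2)s1)Nc1cc(C(F)(F)F)cc(C(F)(F)F)c1` gives 2400 nM, the lower of the two numbers, and the gap between compound 2 and compound 1 lies beyond the usual scatter of this assay. The two structures differ in several places at once, so nothing more than the two numbers themselves can be read from them.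

Compound 3 `O=C(NCCNS(=O)(=O)c1ccc(-c2ccccc2OCc2ccccc2)s1)Nc1cc(C(F)(F)F)cc(C(F)(F)F)c1` has not been measured. It differs from compound 2 in one place: benzyl in place of 3,4-dinitrophenyl on an oxygen on an aromatic ring. For the measured compounds named here, no measured pair in this set shows the effect of such an exchange, so the expectation rests on compound 2 alone. Compound 3 is estimated to give 5000 nM in this assay, with a likely range from 1500 nM to 20000 nM. The expected step is a 2.1-fold higher number from compound 2 to compound 3 (0.32 log units; beyond the scatter), a modest shift toward a weaker inhibitor, though a result within the scatter would not surprise.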

Compound 3, half-maximal inhibitory concentration: > 50000 nM
Compound 3: a limit, no number; the forecaster's own chance of this, stated with the estimate: 10%; middle value at least 10-fold (1.00 log units) from the limit.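

In this assay, for the compounds shown here, the exchange of 3,4-dinitrophenyl for benzyl on an oxygen on an aromatic ring gives an at least 20-fold higher number from compound 2 to compound 3 (1.31 log units; beyond the scatter), the first change in one place in this set, and it shows that this position is far from indifferent to what it carries. Compound 3 stands at a limit, not at a number: the limit of > 50000 nM in this assay, at which 1 of the 3 values shown sits. The exchange removes both nitro groups and the direct attachment of the ring to the oxygen in a single step, so the compounds shown cannot assign the loss to either.

From the compounds shown here alone, whether a plain phenyl on that oxygen would keep the level of compound 2 remains open. So does the outcome for a phenyl carrying one nitro group, or an amine or a carboxylic acid in place of the nitro groups.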